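The source may hold more compounds than are shown below. What is called first, only, known or untested is meant among the compounds shown, and "the series" means these compounds.

Measured in a functional assay on KB cells (Homo sapiens) for antiproliferative activity, read by sulforhodamine B assay, with a stated time of 3 days; on this read-out lower numbers stand for an effect already at smaller amounts and higher numbers for an effect only at larger amounts of compound:
compound 1 `CCC1=C(O)c2c(oc(-c3ccc(CC(C)C)cc3)cc2=O)C(CC)(CC)C1=O`: 29.3 uM
compound 2 `CCC1=C(O)c2c(oc(-c3ccc(O)cc3)cc2=O)C(CC)(CC)C1=O`: 20.6 uM
compound 3 `CCC1=C(O)c2c(oc(-c3ccc(Br)cc3)cc2=O)C(CC)(CC)C1=O`: > 48.1 uM (a limit of the assay)

Compound 3 stands at > 48.1 uM, which is a limit and not a number. Compound 4 `CCC1=C(O)c2c(oc(-c3ccc(F)cc3)cc2=O)C(CC)(CC)C1=O` carries fluoro in place of bromo on an aromatic carbon. Within the data shown here, no measured step makes this exchange directly, so the nearest evidence comes from steps that change the group at the same place. Bromo in place of hydroxy gave an at least 2.3-fold higher number from compound 2 to compound 3 (0.36 log units; beyond the scatter), and bromo in place of isobutyl gave an at least 1.6-fold higher number from compound 1 to compound 3 (0.21 log units; that floor lies within the scatter). Hydroxy in place of isobutyl gave only a 1.4-fold lower number from compound 1 to compound 2 (0.15 log units; within the scatter). Given these steps, a modest move towards a lower number is expected in this assay, hardly beyond the scatter, and compound 4 may also report only a limit. The expected change is an at least 1.3-fold lower number from compound 3 to compound 4 (0.13 log units; that floor lies within the scatter). For compound 4 the estimated value is 35 uM, with an expected range from 18 uM to 60 uM.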

Compound 4, concentration for half-maximal effect: 33 uM
Compound 4: the middle estimate sits 1.1-fold (0.03 log units) above what was measured, and the stated range covers the measured number.
By their numbers in this assay, from the lowest: compounds 2, 1 and 4 (each within the scatter of the next). At a limit, above all of these: compound 3.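

In this assay, fluoro on this aromatic carbon gives a number where bromo gave only a limit, so the exchange can be read only as a floor: an at least 1.4-fold lower number from compound 3 to compound 4 (0.16 log units; that floor lies within the scatter). Compound 4 also falls in with the two other compounds that have numbers, with fluoro in place of hydroxy giving a 1.6-fold higher number from compound 2 to compound 4 (0.20 log units; within the scatter) and fluoro in place of isobutyl giving a 1.1-fold higher number from compound 1 to compound 4 (0.05 log units; within the scatter), so hydroxy, isobutyl and fluoro cannot be told apart at this position. Compound 3 alone stays at a limit, which is not a number: the limit of > 48.1 uM in this assay, at which 1 of the 4 values shown sits.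

Going by these compounds, whether any group at this position can bring the number clearly under those of compound 1, compound 2 and compound 4 stays open. An amine, a carboxylic acid or a longer chain in the same place would test how far this flat stretch reaches.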